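The source may report more compounds than this note shows. Statements on the series, on what has been measured and on what is new or still open speak of the compounds shown alone.

The series rests on a shared core carried by compound 1, `CCCCCCCc1ccc2nc(N)sc2c1`, and compound 2, `C=CCn1c(=N)sc2cc(OC(F)(F)F)ccc21`. In a functional assay on the whole organism with Rattus norvegicus as the target (on this read-out higher numbers stand for an effect only at larger amounts of compound and lower numbers for an effect already at smaller amounts), compound 1 reaches only the limit of the assay, > 10 mg/kg. In this assay compound 2 gives 7 mg/kg, the only number shown for the series. Among the compounds with values here, the one further value, that of compound 1, sits at the limit of the assay, as the limit of > 10 mg/kg in this assay, at which 1 of the 2 values shown sits, records. Compound 3, `CN(C)S(=O)(=O)CCn1c(=N)sc2cc(OC(F)(F)F)ccc21`, has not yet been measured in this assay. It differs from compound 2 in one place: (dimethylsulfamoyl)methyl in place of vinyl on a saturated chain carbon bound to an aromatic nitrogen. Within the data shown here, no step between two measured compounds in this assay is known, so there is nothing measured to set the size of this change against. The step in this assay from compound 2 to compound 3 is expected to be a modest one toward larger doses, a 1.7-fold higher number from compound 2 to compound 3 (0.23 log units; within the scatter), at the edge of the usual scatter. Compound 3 is therefore estimated to give 12 mg/kg in this assay, within a range from 4 mg/kg to 40 mg/kg.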

Compound 3, dose for half-maximal effect: > 10 mg/kg
Compound 3 gave a limit, no number; the forecaster's own chance of this, stated with the estimate: 55%; the middle value lies beyond the limit too.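

Within the data shown here, the step at this position gives the first measured comparison in this assay: an at least 1.4-fold higher number from compound 2 to compound 3 (0.15 log units; that floor lies within the scatter). Among these compounds, this is only a floor, and since it lies within the scatter, it does not establish that (dimethylsulfamoyl)methyl in place of vinyl on a saturated chain carbon bound to an aromatic nitrogen truly moves the dose; it shows only that this exchange, with its 2 hydrogen-bond acceptors entering, did not yield a number under the limit. The result for compound 3 is a limit of the assay and not a number: the limit of > 10 mg/kg in this assay, at which 2 of the 3 values shown sit.

As far as these compounds go, how far compound 3 lies beyond that limit, and so the real size of the step, stays open. Also open, from the compounds shown here alone, is whether a plain propyl chain, an amine or a carboxylic acid at this place would give a measurable dose in this assay.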